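Growing the amine substituent: methyl to 4-fluorobenzyl

This account rests on a few compounds, and the source may have more. Where it says the series, first, only, none or still open, it means among the compounds named here.

Compound 1 `CNc1nc(/C=C/c2ccccc2)nc2ccsc12` is the parent of the pair measured so far. In a functional assay on L02 cells (Homo sapiens) for inhibition, read by Griess assay, with stated times of 1 h and 24 h (on this read-out higher numbers stand for weaker inhibition and lower numbers for stronger inhibition), compound 1 gives > 1000000 nM, which is a limit of the assay and not a number. Its companion compound 2 `CN(C)c1nc(/C=C/c2ccccc2)nc2ccsc12` has methyl in place of hydrogen on a nitrogen on an aromatic ring. In this assay compound 2 gives > 1000000 nM, again a limit of the assay. The step that the two limits leave unreadable from compound 1 to compound 2 cannot be read, because both values sit at the limit of > 1000000 nM in this assay, at which 2 of the 2 values shown sit. On the numbers shown, compound 1 therefore stands only at a limit, and no ranking against compound 2 is possible.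

Compound 3 `Fc1ccc(CNc2nc(/C=C/c3ccccc3)nc3ccsc23)cc1` differs from compound 1 by 4-fluorophenyl in place of hydrogen on a saturated chain carbon bound to a nitrogen on an aromatic ring. For the measured compounds named here, no measured step bears on this change: the single step in hand is unreadable, so there is no basis for expecting a shift in either direction beyond the scatter, nor for ruling one out. The step of an at least 1.2-fold lower number from compound 1 to compound 3 (0.09 log units; that floor lies within the scatter) is thus expected to be small at best. Compound 3 is estimated at 800000 nM, in the range 50000 nM to 3000000 nM, and a further limit rather than a number is expected to be the most likely outcome.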

Compound 3, half-maximal inhibitory concentration: > 1000000 nM
Compound 3: no number, only a limit (the forecaster's own chance of this, stated with the estimate: 70%); middle value at least 1.2-fold (0.09 log units) away from the limit.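

In this assay no step among compound 1, compound 2 and compound 3 can be read, because each stands at a limit of the assay and not at a number: the limit of > 1000000 nM in this assay, at which 3 of the 3 values shown sit.

The compounds shown leave open whether any substituent on this amine nitrogen gives a readable value, and how compound 1, compound 2 and compound 3 rank.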